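Para-methyl on the benzenesulfonyl of an acylsulfonamide series

The compounds below may be only part of what the source reports. "The series", "measured", "known", "first", "only" and "open" are said of these compounds alone.

Among the measured compounds shown here, in an assay on COS7 cells for inhibition of Ectonucleotide pyrophosphatase/phosphodiesterase family member 1 (Homo sapiens), with a stated time of 35 min (on this read-out higher numbers stand for weaker inhibition and lower numbers for stronger inhibition), compound 1 `O=C(NS(=O)(=O)c1ccccc1)n1ccc2cc(Br)cnc21` gives 8300 nM, the highest of the two numbers so far. The one measured partner, compound 2 `O=C(NS(=O)(=O)c1cccc([N+](=O)[O-])c1)n1ccc2cc(Br)cnc21`, gives 1150 nM in this assay, a step of a 7.2-fold lower number from compound 1 to compound 2 (0.86 log units; beyond the scatter). Compound 3 `Cc1ccc(S(=O)(=O)NC(=O)n2ccc3cc(Br)cnc32)cc1` carries the change (methyl in place of hydrogen on an aromatic carbon). For the measured compounds named here, the sole measured step swaps in a nitro group, a different substituent, so it bears on compound 3 only as a sign that this position tolerates substitution. A small step, likely inside the scatter, is therefore expected, read as a 1.4-fold lower number from compound 1 to compound 3 (0.14 log units; within the scatter). Compound 3 is estimated at 6000 nM, within 2500 nM to 15000 nM.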

Compound 3, half-maximal inhibitory concentration: 1550 nM
Estimate against measurement, compound 3: 3.9-fold (0.59 log units) above; measured number outside the range, below it.
By their numbers in this assay, from the lowest: compounds 2 and 3 (each within the scatter of the next); then compound 1.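

The phenyl to 4-methylphenyl change alone gives a clear step in this assay, with a 5.4-fold lower number from compound 1 to compound 3 (0.73 log units; beyond the scatter) on the read-out. A single methyl para to a large group is therefore enough to move the number beyond the scatter, so a lower number than that of compound 1 is not confined to the nitro group of compound 2. No evidence at hand bears on the reason for this step.

As far as these compounds go, whether an ethyl, a methoxy, an amine or a carboxylic acid at this position would lower the number further remains open. So does the effect of a methyl at the ring position that the nitro group holds in compound 2.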